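A Further Phenyl on Compound 2

A few compounds are considered here, and "the series" means these few. Any claim that something is new, unique, unknown or untested is made for them only; others in the source may bear on it.

In a functional assay on U-937/GTB cells (Homo sapiens) for cytotoxicity (on this read-out lower numbers stand for stronger inhibition and higher numbers for weaker inhibition), compound 1 `C=CCn1c[n+](C/C=C(\C)CC/C=C(\C)CC/C=C(\C)CCC=C(C)C)c2/c(=N/OC)[nH]cnc21` gives 1390 nM and compound 2 `CO/N=c1\[nH]cnc2c1[n+](C/C=C(\C)CC/C=C(\C)CC/C=C(\C)CCC=C(C)C)cn2Cc1ccccc1` gives 1070 nM so the two stand level within the usual scatter. Compound 3 `CO/N=c1\[nH]cnc2c1[n+](C/C=C(\C)CC/C=C(\C)CC/C=C(\C)CCC=C(C)C)cn2C(c1ccccc1)c1ccccc1` is still unmeasured. Its change from compound 2 phenyl in place of hydrogen on a saturated chain carbon bound to an aromatic carbon and an aromatic nitrogen is phenyl in place of hydrogen on a saturated chain carbon bound to an aromatic carbon and an aromatic nitrogen. Among the measured compounds shown here, the only measured step that bears on this is a 1.3-fold lower number from compound 1 to compound 2 (0.11 log units; within the scatter) and it also brought in a phenyl, there where compound 1 carries a vinyl. That step stayed within the scatter, so no step beyond the scatter is expected in this assay here, though one example is thin evidence. The estimated move is a 1.1-fold lower number from compound 2 to compound 3 (0.03 log units; within the scatter) and it remains a cautious guess. Compound 3 is expected at 1000 nM with an estimated range from 450 nM to 2200 nM for now.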

Compound 3, half-maximal inhibitory concentration: 1970 nM
Compound 3: middle estimate off by 2.0-fold (0.29 log units), on the low side, and the stated range covers the measured number.
By their numbers in this assay, from the lowest: compounds 2, 1 and 3 (each within the scatter of the next).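

Adding a second phenyl to the saturated chain carbon bound to an aromatic carbon and an aromatic nitrogen gives a 1.8-fold higher number from compound 2 to compound 3 (0.27 log units; within the scatter) in this assay. Among the compounds shown here, until now, the only change seen at this site was a phenyl taking the place of a vinyl on the chain carbon, and that step also stayed within the scatter; this result shows that the same holds when a phenyl replaces a hydrogen on that carbon, bringing in six more heavy atoms. No measurement shown here accounts for this result.

As far as these compounds go, whether an amine or a carboxylic acid on one of the phenyl rings would give a step beyond the scatter remains open. The same question stands for a longer chain in place of the second phenyl.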